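The compounds below may be only part of what the source reports. "The series", "measured", "known", "first", "only" and "open" are said of these compounds alone.

Measured in a functional assay on A549 cells (Homo sapiens) for cytotoxicity, read by MTT assay, with a stated time of 48 h; on this read-out higher numbers stand for weaker inhibition and lower numbers for stronger inhibition:
- Compound 1 `C=CC(C)(O)CC[C@@H]1C(=C)CC[C@H](Br)[C@@]1(C)CCC(O)C(C)(C)Cl`: 94100 nM
- Compound 2 `C=CC(C)(O)CC[C@@H]1C(=C)CC[C@H](Br)[C@@]1(C)CCC(Br)C(C)(C)O`: > 100000 nM; 86900 nM (2 entries)

Within the data shown here, compound 1, at 94100 nM, is the only compound here with a single number, and a number this high on the scale stands for weak inhibition. Compound 2 has two entries, (the several entries of compound 2 in this assay, > 100000 nM; 86900 nM (2 entries)), and one of them is a limit of the assay rather than a number.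

Compound 3 `C=CC(C)(O)CC[C@@H]1C(=C)CC[C@H](Br)[C@@]1(C)CCC(O)C(C)(C)O` has not yet been measured. It departs from compound 1 at one place: hydroxy in place of chloro on a saturated chain carbon bound to three saturated chain carbons. That is, it has hydroxy in place of chloro on a saturated chain carbon bound to three saturated chain carbons.

Among the measured compounds shown here, no pair of measured compounds shows this exchange, so there is no direct step to serve as a guide. In this assay, the expectation is therefore for no change beyond the usual scatter, in either direction. The estimated step is a 1.1-fold higher number from compound 1 to compound 3 (0.03 log units; within the scatter). For compound 3 the expected value is 100000 nM, with an estimated range of 55000 nM to 180000 nM.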

Compound 3, half-maximal inhibitory concentration: > 100000 nM
Compound 3 gave a limit, no number; the forecaster's own chance of this, stated with the estimate: 45%; the middle value lies on the limit itself.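

In this assay, hydroxy in place of chloro on a saturated chain carbon bound to three saturated chain carbons can be read only as a floor: an at least 1.0-fold higher number from compound 1 to compound 3 (0.02 log units; that floor lies within the scatter). Among these compounds, this is the first direct look at this exchange, and it gives no sign that hydroxy at this place brings stronger inhibition than chloro, though that floor does not separate the two compounds beyond the usual scatter. The value of compound 3, > 100000 nM, is a limit of the assay and not a number, and such limits mark how far this set can be read: the limit of > 100000 nM in this assay, at which 1 of the 3 values shown sits.

The compounds shown leave open how far the number of compound 3 actually lies from that of compound 1, so the exchange may turn out to matter or not to matter at all. They also leave open whether a different group at this place, such as an amine or a carboxylic acid, would bring the number down into a range where steps between compounds can be measured in full.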